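A second amide methyl on compound 3

A few compounds are considered here, and "the series" means these few. Any claim that something is new, unique, unknown or untested is made for them only; others in the source may bear on it.

In a physicochemical assay for solubility, at pH 7.4 (on this read-out lower numbers stand for lower solubility and higher numbers for higher solubility), compound 1 (`Cc1oc(-c2ccc(Cl)cc2)nc1C(=O)N[C@H]1CN(S(=O)(=O)c2ccccc2)C[C@@H]1C(=O)N[C@H]1CCCNC1`) gives 15000 nM and compound 2 (`O=C(N[C@H]1CN(S(=O)(=O)c2ccccc2)C[C@@H]1C(=O)N[C@H]1CCCNC1)c1cc(-c2ccccc2Cl)on1`) gives 12000 nM as its value, two numbers within the usual scatter of each other. Compound 3 (`CN(C(=O)c1cc(-c2ccccc2Cl)on1)[C@H]1CN(S(=O)(=O)c2ccccc2)C[C@@H]1C(=O)N[C@H]1CCCNC1`) gives 655000 nM in this assay and stands highest of the three, beyond the scatter from both.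

Compound 4 (`CN(C(=O)[C@H]1CN(S(=O)(=O)c2ccccc2)C[C@@H]1N(C)C(=O)c1cc(-c2ccccc2Cl)on1)[C@H]1CCCNC1`) keeps compound 3 unchanged except for one replacement: methyl in place of hydrogen on an amide-type nitrogen (methyl in place of hydrogen on an amide-type nitrogen whose other neighbours are a carbonyl carbon and a saturated ring carbon).

Among the measured compounds shown here, one measured step bears on this. The same replacement on a different amide-type nitrogen gave a 55-fold higher number from compound 2 to compound 3 (1.74 log units; beyond the scatter) and counts as a large step. This is a single precedent, and the data do not show whether it carries over to a second methyl. A move in the same direction is therefore expected in this assay, with a clearly smaller size than that precedent, since compound 3 already reads 655000 nM as a starting point.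

The estimated change is a 2.3-fold higher number from compound 3 to compound 4 (0.36 log units; beyond the scatter) and remains an expectation only. For compound 4 the expected value is 1500000 nM (estimated range 400000 nM to 5000000 nM) and awaits measurement.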

Compound 4, solubility: 553000 nM
The estimate for compound 4 lay 2.7-fold (0.43 log units) above the measured number; the range from low to high includes it.
By their numbers in this assay, from the lowest: compounds 2 and 1 (each within the scatter of the next); then compounds 4 and 3 (each within the scatter of the next).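

In this assay the result is a 1.2-fold lower number from compound 3 to compound 4 (0.07 log units; within the scatter) for methyl in place of hydrogen on the amide-type nitrogen whose other neighbours are a carbonyl carbon and a saturated ring carbon, so at this position the replacement leaves the read-out where compound 3 had it. The same replacement on the other amide-type nitrogen gave a 55-fold higher number from compound 2 to compound 3 (1.74 log units; beyond the scatter) and counts as a large step, so in these two steps the outcome differs with the nitrogen that carries the methyl, and the size of one step does not carry over to the other. Nothing at hand accounts for this difference between the two nitrogens.

Still open, as far as these compounds go, is how a methyl on this nitrogen reads on its own, with the amide hydrogen kept on the other nitrogen, as compound 3 and compound 4 both carry the first methyl. Also open, from the compounds shown here alone, is whether a longer chain such as ethyl, or a chain ending in an amine or a carboxylic acid, on this same nitrogen would stay as flat as methyl does here.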